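The source may hold more compounds than are shown below. What is called first, only, known or untested is meant among the compounds shown, and "the series" means these compounds.

Measured so far in a functional assay on DU-145 cells (Homo sapiens) for antiproliferative activity, read by MTT assay, with a stated time of 72 h; on this read-out higher numbers stand for weaker inhibition and lower numbers for stronger inhibition:

- compound 1 `COc1cc2c(Nc3ccc(C#N)cc3)ncnc2cc1OCCCN(C)C`: compound 1 gives 35300 nM
- compound 2 `COc1cc2c(Nc3ccc(C#N)cc3)ncnc2cc1OCCCN1CCC(C)CC1`: compound 2 gives 16600 nM
- compound 3 `COc1cc2c(Nc3ccc(C#N)cc3)ncnc2cc1OCCCN1CCCCC1CCO`: for compound 3 the read-out is a limit of the assay, > 100000 nM, as noted in the limit of > 100000 nM in this assay, at which 1 of the 3 values shown sits.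

Compound 3 therefore stands only as a limit among the numbers shown; no measured value places it. The step to compound 4 `COc1cc2c(Nc3ccc(C#N)cc3)ncnc2cc1OCCCN1CCC(c2ccccc2)CC1` is 4-phenylpiperidin-1-yl in place of 2-(2-hydroxyethyl)piperidin-1-yl on a saturated chain carbon, three bonds along the chain from an oxygen on an aromatic ring. The measured steps that bear on it run the other way, toward the limit: an at least 6.0-fold higher number from compound 2 to compound 3 (0.77 log units; beyond the scatter) and an at least 2.8-fold higher number from compound 1 to compound 3 (0.45 log units; beyond the scatter), both beyond the scatter. Among the measured variations at this position, a 2.1-fold lower number from compound 1 to compound 2 (0.33 log units; beyond the scatter) shows that a ring on the chain nitrogen can give the lower number. Compound 4 carries a 4-substituted piperidine like compound 2, so the step of an at least 6.6-fold lower number from compound 3 to compound 4 (0.82 log units; beyond the scatter) is expected to go toward a lower number in this assay, beyond the scatter, reversing the move that produced the limit. The estimate for compound 4 is 15000 nM, within 4000 nM to 60000 nM.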

Compound 4, half-maximal inhibitory concentration: 6790 nM
For compound 4 the middle estimate is 2.2-fold (0.34 log units) above the measured one, within the range that was stated.
By their numbers in this assay, from the lowest: compound 4; then compound 2; then compound 1. At a limit, above all of these: compound 3.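

In this assay phenyl in place of methyl on a saturated ring carbon gives a 2.4-fold lower number from compound 2 to compound 4 (0.39 log units; beyond the scatter) and 4-phenylpiperidin-1-yl in place of dimethylamino gives a 5.2-fold lower number from compound 1 to compound 4 (0.72 log units; beyond the scatter) and so compound 4 holds the lowest number shown. Compound 3 stands only at a limit: the limit of > 100000 nM in this assay, at which 1 of the 4 values shown sits. The step to that limit's far side is an at least 14-fold lower number from compound 3 to compound 4 (1.16 log units; beyond the scatter) and it shows that a piperidine ring on this chain does not by itself bring the limit, so the outcome follows the substituents on the ring and not the ring alone.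

Open, on these data alone, is whether the phenyl ring itself matters or only the size of the group, which a 4-cyclohexylpiperidin-1-yl or 4-benzylpiperidin-1-yl group would separate. Also open, as far as these compounds go, is whether the hydroxyl of compound 3 or its place on the ring goes with the limit, which a 4-(2-hydroxyethyl)piperidin-1-yl group would test.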